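The compounds below may be only part of what the source reports. "The series", "measured", "known", "first", "only" and "open" are said of these compounds alone.

Two compounds share a core and differ only in the aromatic group carried on a saturated chain carbon. Compound 1 `N/C(=N/NC(CC(=O)c1ccc(-n2ccnc2)cc1)c1ccc(F)cc1)c1ccccn1` carries a 4-fluorophenyl there, and in an ADME assay on Vero cells (Chlorocebus sabaeus) for cytotoxicity, read by MTT assay, with a stated time of 72 h (a lower number here means that less compound is tolerated, a higher number that more compound is tolerated), compound 1 gives 78800 nM. Compound 2 `N/C(=N/NC(CC(=O)c1ccc(-n2ccnc2)cc1)c1ccccc1[N+](=O)[O-])c1ccccn1` carries a 2-nitrophenyl instead, and in this assay compound 2 gives 48000 nM. The step of a 1.6-fold lower number from compound 1 to compound 2 (0.22 log units; within the scatter) is the only measured one, and it lies within the scatter, so compound 2 stands with the lowest of two numbers but not apart from compound 1.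

Compound 3 `N/C(=N/NC(CC(=O)c1ccc(-n2ccnc2)cc1)c1ccccc1Cl)c1ccccn1` is the next variation: chloro in place of nitro on an aromatic carbon. For the measured compounds named here, the only comparable step, a 1.6-fold lower number from compound 1 to compound 2 (0.22 log units; within the scatter), shows that exchanging the aromatic group at this position left this assay essentially unmoved, so no step beyond the scatter is expected here either, and the expected step of a 1.1-fold higher number from compound 2 to compound 3 (0.06 log units; within the scatter) is flat. Compound 3 is therefore estimated at 55000 nM in this assay, with a range from 25000 nM to 120000 nM.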

Compound 3, half-maximal cytotoxic concentration: 53200 nM
Estimate against measurement, compound 3: 1.0-fold (0.01 log units) above; measured number inside the range.
By their numbers in this assay, from the lowest: compounds 2, 3 and 1 (each within the scatter of the next).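

Exchanging nitro for chloro on this aromatic carbon, ortho to a large group, removes a group with 2 hydrogen-bond acceptors and puts one with none in its place, yet this assay barely registers it (a 1.1-fold higher number from compound 2 to compound 3 (0.04 log units; within the scatter)). The 2-chlorophenyl in place of 4-fluorophenyl on the saturated chain carbon likewise stays within the scatter (a 1.5-fold lower number from compound 1 to compound 3 (0.17 log units; within the scatter)), so all three aromatic groups shown give numbers within the scatter of the next, and none of them goes against this. Nothing available explains this flatness.

From the compounds shown here alone, whether this tolerance extends to an amine or a carboxylic acid on the aromatic ring remains open. So does the outcome of replacing the whole aromatic group on that chain carbon with a plain alkyl chain.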